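Benzyl substituent change in the shared core

The compounds below may be only part of what the source reports. "The series", "measured", "known", "first", "only" and "open" are said of these compounds alone.

Compound 2 `CCN(Cc1cccc(C)c1)C(=O)C1CCN(S(=O)(=O)c2ccc3cn[nH]c3c2)CC1` gives 78% in a functional assay on CHO cells for positive allosteric modulation of muscarinic acetylcholine receptor M5 (Homo sapiens), read by calcium flux; a lower number here means a smaller maximal response, a higher number a larger maximal response; compound 1 `CCN(Cc1cccc(OC)c1)C(=O)C1CCN(S(=O)(=O)c2ccc3cn[nH]c3c2)CC1` gives 85%. Within the data shown here, the only recorded step, a number 7 percentage points lower from compound 1 to compound 2 (within the scatter), is the sole one that bears on the next change, and it stays within the scatter. Compound 3 `CCN(Cc1ccccc1C(F)(F)F)C(=O)C1CCN(S(=O)(=O)c2ccc3cn[nH]c3c2)CC1` differs from compound 2 by 2-(trifluoromethyl)phenyl in place of 3-methylphenyl on a saturated chain carbon bound to an amide-type nitrogen. The change is not the same kind as the measured one, so its effect is uncertain, and no step beyond the scatter is expected in this assay: the estimated shift is a number 2 percentage points lower from compound 2 to compound 3 (within the scatter). Compound 3 is therefore expected at 76%, within 55% to 95%.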

Compound 3, largest response reached (reported as percent of maximum), in percent of the reference or control that the assay uses: 92%
For compound 3 the middle estimate is 16 percentage points below the measured one; measured number inside the range.
By their numbers in this assay, from the lowest: compounds 2, 1 and 3 (each within the scatter of the next, the first and the last beyond it).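

Among these compounds, on the saturated chain carbon bound to an amide-type nitrogen, 2-(trifluoromethyl)phenyl in place of 3-methylphenyl gives in this assay a number 14 percentage points higher from compound 2 to compound 3 (beyond the scatter) and is the one step here beyond the scatter. In place of 3-methoxyphenyl the same group gives a number 7 percentage points higher from compound 1 to compound 3 (within the scatter) and does not separate from it. Nothing at hand accounts for the larger step. Open remains whether the trifluoromethyl group itself or its placement on the ring carries that step. On these data alone, how a pyridyl or chlorophenyl group would read at this place is also open.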